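The source may hold more compounds than are shown below. What is called first, only, known or untested is meant among the compounds shown, and "the series" means these compounds.

Compound 1 `Cn1nc(-c2cccnc2)c2ccccc2c1=O`: 63%
Compound 2 `CCCCn1nc(-c2cccnc2)c2ccccc2c1=O`: 91%

In an assay on isolated protein (Oryctolagus cuniculus) with Thromboxane-A synthase (Homo sapiens) as the target, tested at 1 uM (a higher number here means more inhibition at the concentration tested (going by the name of the read-out), a lower number less inhibition), compound 2 stands highest of the two measured numbers; the step of a number 28 percentage points higher from compound 1 to compound 2 (beyond the scatter) lies beyond the scatter. Compound 3 `CCCCCCCCn1nc(-c2cccnc2)c2ccccc2c1=O` grows the same chain further: butyl in place of hydrogen on a saturated chain carbon, four bonds along the chain from an aromatic nitrogen. For the measured compounds named here, only that one earlier step bears on this change, and it was modest. Since compound 2 already sits near the top of the scale, little room remains for a further rise, so a step of a number 2 percentage points higher from compound 2 to compound 3 (within the scatter) is expected, at most a small gain and possibly none beyond the scatter. Compound 3 is therefore estimated at 93%, in the range 80% to 100%.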

Compound 3, a percentage reported as inhibition, at one concentration (the size of the read-out at that concentration, not a potency): 99%
Compound 3: middle estimate off by 6 percentage points, on the low side, within the range that was stated.
By their numbers in this assay, from the lowest: compound 1; then compounds 2 and 3 (each within the scatter of the next).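

In this assay the added butyl gives a number 8 percentage points higher from compound 2 to compound 3 (within the scatter) and so brings no change that can be told apart from the scatter. Heptyl in place of hydrogen on the saturated chain carbon bound to an aromatic nitrogen gives a number 36 percentage points higher from compound 1 to compound 3 (beyond the scatter) and shows that the gain seen with the shorter chain survives at this greater length. Nothing measured here explains either step.

From the compounds shown here alone, whether a still longer chain would hold this level stays open. So does the outcome for an amine or a carboxylic acid at the end of the chain.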